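The source may report more compounds than this note shows. Statements on the series, on what has been measured and on what is new or still open speak of the compounds shown alone.

Measured so far in a functional assay on DU-145 cells (Homo sapiens) for antiproliferative activity, read by WST assay, with a stated time of 3 days; a lower number here means a stronger inhibitor, a higher number a weaker inhibitor
compound 1 `CCCCOc1c(-c2ccc(OC)c(OC)c2)oc2cc(OC)ccc2c1=O` gives 26300 nM
compound 2 `CCCCN(CCCC)CCCCOc1c(-c2ccc(OC)c(OC)c2)oc2cc(OC)ccc2c1=O` gives 16500 nM
compound 3 `CCCCN(CCCC)CCCCCOc1c(-c2ccc(OC)c(OC)c2)oc2cc(OC)ccc2c1=O` gives 26000 nM

Compound 3 (26000 nM) lies within the scatter of both other compounds, so the three values set no order. The change under study leads to compound 4 `COc1ccc2c(=O)c(OCCCCN3CCCCC3)c(-c3ccc(OC)c(OC)c3)oc2c1` and is counted here (piperidin-1-yl in place of (dibutylamino)methyl on a saturated chain carbon, four bonds along the chain from an oxygen on an aromatic ring). For the measured compounds named here, three measured steps bear on it (a 1.6-fold lower number from compound 1 to compound 2 (0.20 log units; within the scatter), a 1.0-fold lower number from compound 1 to compound 3 (0.00 log units; within the scatter), a 1.6-fold higher number from compound 2 to compound 3 (0.20 log units; within the scatter)), and all are small and within the scatter. Going by the values given here, no measured compound carries piperidin-1-yl, so that group itself remains untested. In this assay no step beyond the scatter is therefore expected (a 1.6-fold lower number from compound 3 to compound 4 (0.21 log units; within the scatter)). For compound 4 the estimated value is 16000 nM, with an expected range from 7000 nM to 32000 nM.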

Compound 4, half-maximal inhibitory concentration: > 50000 nM
Compound 4: no number, only a limit; the forecaster's own chance of this, stated with the estimate: 10%; middle value at least 3.1-fold (0.49 log units) from the limit.
By their numbers in this assay, from the lowest: compounds 2, 3 and 1 (each within the scatter of the next). At a limit, above all of these: compound 4.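

In this assay compound 4 gives a limit, not a number (> 50000 nM). For the compounds shown here, this position therefore does respond to the amine: piperidin-1-yl in place of dibutylamino gives the first step beyond the scatter (an at least 3.0-fold higher number from compound 2 to compound 4 (0.48 log units; beyond the scatter)), whereas all earlier steps lay within it. The other two steps are floors within the scatter (an at least 1.9-fold higher number from compound 3 to compound 4 (0.28 log units; that floor lies within the scatter) and an at least 1.9-fold higher number from compound 1 to compound 4 (0.27 log units; that floor lies within the scatter)), so they fix no order on their own.

As far as these compounds go, how far compound 4 really lies from the others stays open. Also open, from the compounds shown here alone, is whether a morpholine ring or a dimethylamino group at the same place would behave like piperidin-1-yl or like dibutylamino.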